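A few compounds are considered here, and "the series" means these few. Any claim that something is new, unique, unknown or untested is made for them only; others in the source may bear on it.

Measured so far:
Compound 1, `Cc1ccc(NC(=O)c2ccc(/N=N\c3c[nH]c4ccccc34)cc2)cc1`, in a functional assay on HCT-116 cells (Homo sapiens) for inhibition, read by MTT assay, with a stated time of 72 h (on this read-out higher numbers stand for weaker inhibition and lower numbers for stronger inhibition), gives 25400 nM.
Compound 2, `O=C(Nc1ccccc1Cl)c1ccc(/N=N\c2c[nH]c3ccccc23)cc1`, in this assay gives 120000 nM.
Compound 3, `Cc1ccccc1NC(=O)c1ccc(/N=N\c2c[nH]c3ccccc23)cc1`, in this assay gives 509000 nM.

Compound 3 stands highest of the three: the step of a 4.2-fold higher number from compound 2 to compound 3 (0.63 log units; beyond the scatter) and the step of a 20-fold higher number from compound 1 to compound 3 (1.30 log units; beyond the scatter) both lie beyond the scatter, so compound 3 is the weakest inhibitor of the set. Compound 4, `O=C(Nc1cccc([N+](=O)[O-])c1)c1ccc(/N=N\c2c[nH]c3ccccc23)cc1`, differs from compound 3 in one place: 3-nitrophenyl in place of 2-methylphenyl on an amide-type nitrogen.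

Among the compounds with values here, no measured step swaps in a 3-nitrophenyl, so the bearing of the known steps is indirect. The step of a 20-fold higher number from compound 1 to compound 3 (1.30 log units; beyond the scatter) shows that the 2-methylphenyl of compound 3 sits far above the 4-methylphenyl of compound 1, and the step of a 4.2-fold higher number from compound 2 to compound 3 (0.63 log units; beyond the scatter) shows it also above the 2-chlorophenyl of compound 2. Both measured changes that arrive at 2-methylphenyl worsen the number, which suggests that leaving it may recover part of the loss, though nothing shows how far. He therefore expects a modest step down in this assay, within the span of the measured compounds, and estimates compound 4 at 100000 nM, in a range from 20000 nM to 500000 nM, which means a step of a 5.1-fold lower number from compound 3 to compound 4 (0.71 log units; beyond the scatter).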

Compound 4, half-maximal inhibitory concentration: 70100 nM
Compound 4: middle estimate off by 1.4-fold (0.15 log units), on the high side, within the range that was stated.
By their numbers in this assay, from the lowest: compound 1; then compounds 4 and 2 (each within the scatter of the next); then compound 3.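

In this assay, within the data shown here, the step of a 7.3-fold lower number from compound 3 to compound 4 (0.86 log units; beyond the scatter) shows for the first time that this position, on the amide-type nitrogen, accepts a group other than a methyl- or chloro-substituted phenyl, and that a change away from 2-methylphenyl does recover part of the loss seen in compound 3. The other two steps place 3-nitrophenyl among the earlier groups: the step of a 1.7-fold lower number from compound 2 to compound 4 (0.23 log units; within the scatter) lies within the scatter, so this assay does not tell 3-nitrophenyl and 2-chlorophenyl apart, while the step of a 2.8-fold higher number from compound 1 to compound 4 (0.44 log units; beyond the scatter) lies beyond it, so the larger 3-nitrophenyl, with its two hydrogen-bond acceptors, does not reach the 4-methylphenyl of compound 1, which remains the strongest inhibitor of the four. Nothing at hand explains why these groups on the amide-type nitrogen differ in this way.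

The compounds shown leave open whether the nitro group itself or its place on the phenyl ring sets the number of compound 4. Also open, as far as these compounds go, is how an amine, a carboxylic acid or a plain phenyl at this position would read in this assay.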